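The compounds below may be only part of what the source reports. "The series", "measured", "known", "first", "only" and "open" are said of these compounds alone.

Compound 3 `Cc1c(C(=O)N/N=C\c2ccco2)oc2cccc(O)c12` was tested in a functional assay on PC-3 cells (Homo sapiens) for inhibition (a higher number here means a weaker inhibitor, a lower number a stronger inhibitor), where compound 3 gives >= 40000 nM, which is a limit of the assay rather than a number. Compound 1 `Cc1c(C(=O)N/N=C\c2cccc(F)c2)oc2cccc(O)c12` gives >= 40000 nM in this assay, also a limit. Among the compounds with values here, compound 2 `Cc1c(C(=O)N/N=C\c2cccc(O)c2O)oc2cccc(O)c12` gives 12200 nM in this assay, the only plain number among the three, and the step of an at least 3.2-fold higher number from compound 2 to compound 3 (0.51 log units; beyond the scatter) shows compound 3 to be the weaker of the two, while the step that the two limits leave unreadable from compound 1 to compound 3 cannot be sized because of the limit of >= 40000 nM in this assay, at which 2 of the 3 values shown sit. Compound 4 `Cc1c(C(=O)N/N=C\c2ccccn2)oc2cccc(O)c12` differs from compound 3 by pyridin-2-yl in place of furan-2-yl on a carbon with a double bond to nitrogen. Both measured steps that touch furan-2-yl at this position lack a readable size, so no step beyond the scatter can be foreseen. Compound 4 is expected to give 40000 nM, between 15000 nM and 100000 nM, a step of a number no higher from compound 3 to compound 4 (the limit leaves the size open).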

Compound 4, half-maximal inhibitory concentration: >= 40000 nM
Compound 4: no number, only a limit; the forecaster's own chance of this, stated with the estimate: 65%; the middle value sits exactly at the limit.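

Compound 4 joins compound 1 and compound 3 at the limit of this assay, so a third group on this carbon, and the first with a nitrogen in its ring, gives no plain number. Only 2,3-dihydroxyphenyl gives one so far, and pyridin-2-yl in its place brings an at least 3.2-fold higher number from compound 2 to compound 4 (0.51 log units; beyond the scatter). The steps among compound 1, compound 3 and compound 4 cannot be read, because all three sit at one limit: the limit of >= 40000 nM in this assay, at which 3 of the 4 values shown sit.

On these data alone, whether 2,3-dihydroxyphenyl needs both hydroxyl groups stays open; a 3-hydroxyphenyl group would test this. As far as these compounds go, how compound 1, compound 3 and compound 4 rank among themselves also stays open.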